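Swapping the Sulfonyl Aryl Group of a Chemokine Receptor Ligand

The source may hold more compounds than are shown below. What is called first, only, known or untested is meant among the compounds shown, and "the series" means these compounds.

Compound 1 `Cc1ccccc1C(=O)NCc1ccc(CNS(=O)(=O)c2ccc(Cl)cc2)cc1` stands lowest of the three measured compounds in an assay on MDA-MB-231 cells for displacement of a labelled ligand from C-X-C chemokine receptor type 4 (Homo sapiens), read by fluorescence and microscopy, with stated times of 10 min and 30 min (on this read-out lower numbers stand for an effect already at smaller amounts and higher numbers for an effect only at larger amounts of compound), giving 1 nM. Compound 2 `O=C(NCc1ccc(CNS(=O)(=O)c2ccc(Cl)cc2)cc1)c1cccnc1` gives 1000 nM and compound 3 `COc1ccccc1C(=O)NCc1ccc(CNS(=O)(=O)c2ccc(Cl)cc2)cc1` gives 1000 nM, both far removed: a 1000-fold higher number from compound 1 to compound 2 (3.00 log units; beyond the scatter) and a 1000-fold higher number from compound 1 to compound 3 (3.00 log units; beyond the scatter), while no change at the digits printed from compound 2 to compound 3 (within the scatter). Compound 4 `Cc1ccccc1C(=O)NCc1ccc(CNS(=O)(=O)c2ccccc2F)cc1` differs from compound 1 in one place: 2-fluorophenyl in place of 4-chlorophenyl on a sulfonyl sulfur. Within the data shown here, no measured step touches the sulfonyl side, so the large steps seen on the carbonyl side cannot be carried over directly; they show only that single changes elsewhere in compound 1 have cost much. A modest weakening is therefore expected for compound 4, a 30-fold higher number from compound 1 to compound 4 (1.48 log units; beyond the scatter). Compound 4 is expected to give 30 nM, within 3 nM to 300 nM.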

Compound 4, effective concentration (reported as EC, without a stated level of effect): 1000 nM
For compound 4 the middle estimate is 33-fold (1.52 log units) below the measured one, outside the stated range (above it).
By their numbers in this assay, from the lowest: compound 1; then compounds 2, 3 and 4 (each within the scatter of the next).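

Among these compounds, the sulfonyl side of compound 1 proves sensitive too: in this assay, 2-fluorophenyl in place of 4-chlorophenyl gives a 1000-fold higher number from compound 1 to compound 4 (3.00 log units; beyond the scatter), a large step at a place the earlier compounds left untouched. The two groups have the same heavy-atom count and the same counts of donors and acceptors, so these counts do not separate them. Nothing available explains the loss. The change alters both the halogen and its ring position, and the compounds shown do not separate the two. Going by these compounds, whether 4-fluorophenyl, 2-chlorophenyl or plain phenyl would keep the low number of compound 1 stays open.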